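Amide nitrogen substituents on the shared core, antiproliferative readout

The source may hold more compounds than are shown below. What is called first, only, known or untested is meant among the compounds shown, and "the series" means these compounds.

Measured so far:
compound 1 `COc1ncc(-c2ccc3c(c2)N(c2ccc(C)cc2)C(=O)CO3)cc1NS(=O)(=O)c1ccc(F)cc1` — 15400 nM
compound 2 `COc1ncc(-c2ccc3c(c2)N(C2CCCCC2)C(=O)CO3)cc1NS(=O)(=O)c1ccc(F)cc1` — 30100 nM

In a functional assay on MCF7 cells (Homo sapiens) for antiproliferative activity, read by MTT assay, with a stated time of 72 h (a lower number here means a stronger inhibitor, a higher number a weaker inhibitor), compound 1 gives 15400 nM. Compound 2, which carries cyclohexyl on the same amide-type nitrogen in a ring, gives 30100 nM. Among the compounds with values here, of the two numbers compound 2 stands highest, its only neighbour being compound 1; the single step is a 2.0-fold higher number from compound 1 to compound 2 (0.29 log units; within the scatter), so the two compounds cannot be ordered on this evidence.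

Compound 3 `COc1ccc(N2C(=O)COc3ccc(-c4cnc(OC)c(NS(=O)(=O)c5ccc(F)cc5)c4)cc32)cc1` is the next member. Its difference from compound 2 is 4-methoxyphenyl in place of cyclohexyl on an amide-type nitrogen in a ring. Within the data shown here, the only measured step that bears on this change is the one from compound 1 to compound 2, in which an aromatic six-membered ring gave way to a saturated one on this nitrogen, a 2.0-fold higher number from compound 1 to compound 2 (0.29 log units; within the scatter), a move that stayed within the scatter. Compound 3 reverses that move, returning an aromatic ring to the nitrogen, now bearing 4-methoxyphenyl rather than 4-methylphenyl. Among the measured compounds shown here, no measured pair speaks to the methoxy group itself.

On this basis the step from compound 2 to compound 3 is expected to be small, a 1.8-fold lower number from compound 2 to compound 3 (0.25 log units; within the scatter), at most a return toward the number of compound 1. For compound 3 the estimate in this assay is 17000 nM, with a range from 7000 nM to 40000 nM.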

Compound 3, half-maximal inhibitory concentration: 8260 nM
Compound 3: middle estimate off by 2.1-fold (0.31 log units), on the high side, and the stated range covers the measured number.
By their numbers in this assay, from the lowest: compounds 3, 1 and 2 (each within the scatter of the next, the first and the last beyond it).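

Within the data shown here, on the amide-type nitrogen in a ring, this assay now gives the first step beyond the scatter, with 4-methoxyphenyl in place of cyclohexyl (a 3.6-fold lower number from compound 2 to compound 3 (0.56 log units; beyond the scatter)), a modest step, whereas the earlier exchange of 4-methylphenyl for cyclohexyl stayed within the scatter. Methoxy in place of methyl on an aromatic carbon also stays within the scatter (a 1.9-fold lower number from compound 1 to compound 3 (0.27 log units; within the scatter)), so compound 1 and compound 3 cannot be ordered, and only compound 2 and compound 3 are separated among the three. No measured evidence is available to explain this separation.

Open, going by these compounds, is whether an unsubstituted phenyl, a phenyl ring carrying an amine or a carboxylic acid, or a longer alkyl chain on this nitrogen would fall with compound 3, with compound 2, or elsewhere. Also open, on these data alone, is whether the separation of compound 2 and compound 3 holds in any read-out other than this assay, or with a different group on the rest of the shared core.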